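The source may hold more compounds than are shown below. What is called first, only, known or untested is meant among the compounds shown, and "the series" means these compounds.

Measured compounds:
- compound 1, `Cc1ccc(S(=O)(=O)Cc2nc3c(Cn4ccnc4)c(O)ccc3n2C)cc1`: 506000 nM
- compound 2, `Cn1c(CSc2ccccc2)nc2c(CN3CCCC3)c(O)ccc21`: 227000 nM
- compound 3, `Cn1c(CSc2ccc(F)cc2)nc2c(CN3CCCC3)c(O)ccc21`: 74800 nM

In an ADME assay on HepG2 2.2.15 cells (Homo sapiens) for cytotoxicity, with a stated time of 9 days (on this read-out higher numbers stand for lower toxicity in this test and lower numbers for higher toxicity in this test), compound 1 gives 506000 nM, the highest of the three numbers; compound 2 gives 227000 nM, and compound 3 gives 74800 nM. Compound 4, `Cn1c(CS(=O)(=O)c2ccccc2)nc2c(Cn3ccnc3)c(O)ccc21`, is the next compound to be measured. It differs from compound 1 in a single place: hydrogen in place of methyl on an aromatic carbon.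

Going by the values given here, only one measured step changes a single substituent on an aromatic ring: a 3.0-fold lower number from compound 2 to compound 3 (0.48 log units; beyond the scatter). That step puts fluoro in place of hydrogen on a different part of the shared core, and compounds 2 and 3 also differ from compound 1 in other places, so it bears on the present change only loosely. Among the compounds with values here, no measured pair shows what removing a methyl from this ring does. With only this to go on, the step from compound 1 to compound 4 is expected to be small, likely within the usual scatter, and with no clear direction; the estimate is a 1.1-fold lower number from compound 1 to compound 4 (0.05 log units; within the scatter). Compound 4 is therefore expected to come in near 450000 nM, within a range of 200000 nM to 1000000 nM.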

Compound 4, half-maximal cytotoxic concentration: 623000 nM
Compound 4: middle estimate off by 1.4-fold (0.14 log units), on the low side; measured number inside the range.
By their numbers in this assay, from the lowest: compound 3; then compound 2; then compounds 1 and 4 (each within the scatter of the next).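

In this assay, replacing the methyl para to a large group with hydrogen, so that 4-methylphenyl becomes phenyl, gives a 1.2-fold higher number from compound 1 to compound 4 (0.09 log units; within the scatter) and leaves the read-out within the scatter. Going by these compounds alone, this is the first measured step at this place, and it shows that this single methyl can go without a change that stands out from repeat-measurement noise, at least between these two compounds; the only earlier step of one substituent on an aromatic ring, a 3.0-fold lower number from compound 2 to compound 3 (0.48 log units; beyond the scatter), lies beyond the scatter, but it concerns a different substituent in a different pair, so the two steps set no common rule. Nothing available here offers an explanation for the result.

The compounds shown carry only methyl or hydrogen at this place, so it remains open whether a larger or different group, such as a methoxy, an amine or a carboxylic acid, would move the number beyond the scatter. From the compounds shown here alone, it also remains open whether fluoro at this place, on the phenyl of compound 4, would lower the number as it does in the step to compound 3.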